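The source may report more compounds than this note shows. Statements on the series, on what has been measured and on what is new or still open speak of the compounds shown alone.

Measured so far in a functional assay on KB cells (Homo sapiens) for cytotoxicity; a higher number here means a weaker inhibitor, a lower number a stronger inhibitor:
compound 1 `Cc1ccc(Cn2cc(C(=N)S)c3c(N)ncnc32)cc1`, with 65000 nM.
compound 2 `Cc1ccccc1Cn1cc(C(=N)S)c2c(N)ncnc21`, which returns only a limit of > 17000 nM.

Among the compounds with values here, compound 1 is thus the only compound with an actual number in this assay ; the other entry is a limit, not a number. The step that the limit leaves unreadable from compound 1 to compound 2 cannot be sized, since (the limit of > 17000 nM in this assay, at which 1 of the 2 values shown sits).

Compound 3 `Cc1ccc(Cn2cc(C(N)=O)c3c(N)ncnc32)cc1` differs from compound 1 by a group of 3 heavy atoms (1 carbon, 1 nitrogen, 1 oxygen; no ring) in place of a group of 3 heavy atoms (1 carbon, 1 nitrogen, 1 sulfur; no ring), on an aromatic carbon. Within the data shown here, no measured step covers this change; the only step recorded, from compound 1 to compound 2, concerns a different position and is unreadable anyway. With nothing bearing on the change, no shift beyond the scatter is expected, and the step of no change at the digits printed from compound 1 to compound 3 (within the scatter) is estimated to be small. Compound 3 is therefore expected near 65000 nM, in the range 20000 nM to 200000 nM, with a real chance that this assay again reports only a limit.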

Compound 3, half-maximal inhibitory concentration: > 100000 nM
Compound 3: no number, only a limit (the forecaster's own chance of this, stated with the estimate: 40%); middle value at least 1.5-fold (0.18 log units) from the limit.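

Compound 3 returns only a limit in this assay, > 100000 nM, and not a number. Carbamoyl in place of the sulfur-bearing group on this aromatic carbon gives an at least 1.5-fold higher number from compound 1 to compound 3 (0.18 log units; that floor lies within the scatter), so this is the first readable step in the series, although its floor does not establish a shift beyond the scatter. The actual size of the step remains undefined, and compound 1 is still the only compound with a number: the limit of > 100000 nM in this assay, at which 1 of the 3 values shown sits.

From the compounds shown here alone, the step to the 2-methylphenyl compound 2 still cannot be read, so the effect of the change on the saturated chain carbon also remains open. Going by these compounds, it is also open whether a nitrile or a carboxylic acid on this aromatic carbon would give a number rather than a limit in this assay.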